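Distant Aryl Swap Leaves Acid Dissociation Unmoved

A few compounds are considered here, and "the series" means these few. Any claim that something is new, unique, unknown or untested is made for them only; others in the source may bear on it.

Compound 3 `COc1cccc(CNCCCNc2ccnc3cc(Cc4ccc(C#N)cc4)ccc23)c1O` gives 9.47 in a physicochemical assay for acid dissociation. On this number it stands level with compound 1 `COc1cccc(CNCCCNc2ccnc3cc(CCC(C)C)ccc23)c1O`, which gives 9.47, and with compound 2 `COc1cccc(CNCCCNc2ccnc3cc(-c4ccccc4)ccc23)c1O`, which gives 9.47. Every measured step altered the same distant group on the shared core, and each stayed within the scatter: no change at the digits printed from compound 1 to compound 2 (within the scatter), no change at the digits printed from compound 1 to compound 3 (within the scatter) and no change at the digits printed from compound 2 to compound 3 (within the scatter). Compound 4 `COc1cccc(CNCCCNc2ccnc3cc(Cc4cccc(C(F)(F)F)c4)ccc23)c1O` changes that same position once more: 3-(trifluoromethyl)phenyl in place of 4-cyanophenyl on a saturated chain carbon bound to an aromatic carbon. The three earlier steps at this position each held steady, so the step of no change at the digits printed from compound 3 to compound 4 (within the scatter) is expected to be no change beyond the scatter. Compound 4 is therefore estimated at 9.47, with a range from 9.2 to 9.75.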

Compound 4, acid dissociation constant: 9.47
Compound 4: the middle estimate sits on the measured number at the digits printed; measured number inside the range.
By their numbers in this assay, from the lowest: compounds 1, 2, 3 and 4 (each within the scatter of the next).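

In this assay, replacing 4-cyanophenyl with 3-(trifluoromethyl)phenyl exchanges a nitrile, with its hydrogen-bond acceptor, for three fluorine atoms on a larger group, and the result is flat (no change at the digits printed from compound 3 to compound 4 (within the scatter)). Compound 4 also stays level with the two other groups at this position (no change at the digits printed from compound 2 to compound 4 (within the scatter); no change at the digits printed from compound 1 to compound 4 (within the scatter)). No evidence here explains this flatness. Still open, from the compounds shown here alone, is whether an amine or a carboxylic acid at this position would hold the number level in this assay, and whether changes elsewhere on the shared core would.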